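Swapping the pyrazole for an indazole on the shared core

The source may report more compounds than this note shows. Statements on the series, on what has been measured and on what is new or still open speak of the compounds shown alone.

Measured so far:
- Compound 1 `Nc1ccc(S(=O)(=O)N2CCN(c3ncc(C(O)(C(F)(F)F)C(F)(F)F)cc3C#CCO)CC2)cn1`: 65 mL.min-1.g-1
- Compound 2 `CC(C)(C)n1cc(-c2cc(C(O)(C(F)(F)F)C(F)(F)F)cnc2N2CCN(S(=O)(=O)c3ccc(N)nc3)CC2)cn1`: 459 mL.min-1.g-1

In an ADME assay (liver) for metabolic stability, with Liver microsome (Rattus norvegicus) as the target, using microsomes and NADPH, with a stated time of 30 min, tested at 1 uM (on this read-out lower numbers stand for slow clearance and higher numbers for fast clearance), compound 2 gives the higher of the two numbers shown; its nearest neighbour is compound 1, and the only measured step, a 7.1-fold higher number from compound 1 to compound 2 (0.85 log units; beyond the scatter), runs between them. That step shows the clearance readout responds strongly to what sits at this position on the shared core.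

Compound 3 `Nc1ccc(S(=O)(=O)N2CCN(c3ncc(C(O)(C(F)(F)F)C(F)(F)F)cc3-c3ccc4[nH]ncc4c3)CC2)cn1` is not yet measured. It differs from compound 2 in one place: 1H-indazol-5-yl in place of 1-(tert-butyl)-1H-pyrazol-4-yl on an aromatic carbon

Within the data shown here, no measured step covers this exact exchange, so the expectation rests only on a 7.1-fold higher number from compound 1 to compound 2 (0.85 log units; beyond the scatter), which shows that changing the group at this position can move the number well beyond the scatter. Compound 3 is therefore expected to sit below compound 2, with the step of a 3.1-fold lower number from compound 2 to compound 3 (0.49 log units; beyond the scatter) estimated as a clear decrease. The estimate for compound 3 in this assay is 150 mL.min-1.g-1, with a likely range from 50 mL.min-1.g-1 to 400 mL.min-1.g-1.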

Compound 3, intrinsic clearance in microsomes: 88 mL.min-1.g-1
The estimate for compound 3 lay 1.7-fold (0.23 log units) above the measured number, within the range that was stated.
By their numbers in this assay, from the lowest: compounds 1 and 3 (each within the scatter of the next); then compound 2.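

In this assay the exchange of 1-(tert-butyl)-1H-pyrazol-4-yl for 1H-indazol-5-yl gives a 5.2-fold lower number from compound 2 to compound 3 (0.72 log units; beyond the scatter) and so shows that two groups with the same count of heavy atoms can still differ clearly at this position. The step of a 1.4-fold higher number from compound 1 to compound 3 (0.13 log units; within the scatter) adds that 1H-indazol-5-yl and 3-hydroxyprop-1-yn-1-yl cannot be told apart here, which leaves compound 2 alone at the fast-clearance end of these three. No measurement at hand gives a reason for either step.

The compounds shown leave open whether the tert-butyl group itself goes with the high number of compound 2. A 1-methyl-1H-pyrazol-4-yl group would speak to that question, while an amine or a carboxylic acid at this position remains an open case.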